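From a butyl chain back to an oxygen-bearing five-membered ring

The source may report more compounds than this note shows. Statements on the series, on what has been measured and on what is new or still open speak of the compounds shown alone.

Of the compounds shown here, three built on one shared core have been measured in a functional assay on the whole organism with Mus musculus as the target; on this read-out lower numbers stand for smaller maximal responses and higher numbers for larger maximal responses. Compound 1 `C=CCn1c(=O)n(C2CCC(CO)C2)c2nc(N)nc(O)c21` gives 0%. Compound 2 `C=CCn1c(=O)n([C@H]2CO[C@@H](CO)C2)c2nc(N)nc(O)c21` gives 16%. Compound 3 `C=CCn1c(=O)n(CCCC)c2nc(N)nc(O)c21` gives 36%, the highest of the three numbers; the steps leading to it are a number 36 percentage points higher from compound 1 to compound 3 (beyond the scatter) and a number 20 percentage points higher from compound 2 to compound 3 (beyond the scatter), while between the two ring-bearing compounds the step is a number 16 percentage points higher from compound 1 to compound 2 (beyond the scatter).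

Compound 4 `C=CCn1c(=O)n(C2C=CC(CO)O2)c2nc(N)nc(O)c21` has not yet been measured. It differs from compound 3 by a group of 7 heavy atoms (5 carbon, 2 oxygen; one five-membered non-aromatic ring with 1 hetero atom) in place of a group of 4 heavy atoms (4 carbon; no ring), on an aromatic nitrogen. Among the compounds with values here, the step that bears most directly on this change is the one from compound 2 to compound 3, in which a five-membered non-aromatic ring with one hetero atom was replaced by butyl and the number rose by a modest amount; the step from compound 1 to compound 3 points the same way and was large. Compound 4 reverses that kind of exchange, so the expectation is a modest fall, of about a number 18 percentage points lower from compound 3 to compound 4 (beyond the scatter), landing near where compound 2 stands. Compound 4 is therefore estimated at 18% in this assay, with a range from 5% to 32%.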

Compound 4, largest response reached (reported as maximal response), in percent of the reference or control that the assay uses: 84%
Estimate against measurement, compound 4: 66 percentage points below, outside the stated range (above it).
By their numbers in this assay, from the lowest: compound 1; then compound 2; then compound 3; then compound 4.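

In this assay, the group on the aromatic nitrogen can carry the response well past butyl, with a number 48 percentage points higher from compound 3 to compound 4 (beyond the scatter), so the order among compound 1, compound 2 and compound 3, in which butyl stood highest, does not extend to every ring-bearing group. Two groups of the same atom make-up also part widely, with a number 68 percentage points higher from compound 2 to compound 4 (beyond the scatter), and the ring of carbon only lies further off still, with a number 84 percentage points higher from compound 1 to compound 4 (beyond the scatter); across these four compounds, then, the response follows the detailed form of the ring and not merely the presence of a ring or of a hetero atom in it. Nothing available here accounts for this rise.

Compound 4 differs from compound 2 both in its double bond and in how its ring is built, so the compounds shown cannot tell which of the two carries the gain. Also open, from the compounds shown here alone, is whether the hydroxymethyl group is needed at all, and how an amine or a carboxylic acid in its place would fare in this assay.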